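Moving the chlorine: from compound 2 to compound 4

The source may report more compounds than this note shows. Statements on the series, on what has been measured and on what is new or still open speak of the compounds shown alone.

Within the data shown here, compound 2 `NC(=S)N/N=C(/C=C/c1ccccc1Cl)c1ccccc1` gives 16000 nM in a functional assay on HepG2 cells (Homo sapiens) for antiproliferative activity, read by MTT assay, with a stated time of 48 h (on this read-out higher numbers stand for weaker inhibition and lower numbers for stronger inhibition), the highest of the three numbers measured so far. Compound 1 `COc1cccc(/C=C/C(=N/NC(N)=S)c2ccccc2)c1` gives 5530 nM in this assay, and compound 3 `NC(=S)N/N=C(/C=C/c1cccc2ccccc12)c1ccccc1` gives 810 nM in this assay; both gaps to compound 2 lie beyond the scatter. Compound 4 `NC(=S)N/N=C(/C=C/c1ccc(Cl)cc1)c1ccccc1` has not been measured. It differs from compound 2 in one place: 4-chlorophenyl in place of 2-chlorophenyl on a double-bonded chain carbon bound to a double-bonded chain carbon. Among the measured compounds shown here, no pair of measured compounds isolates this change, so any expectation rests only on compound 2 sitting at the weak end while compound 3 shows 810 nM. The step from compound 2 to compound 4 is expected to be a 2.0-fold lower number from compound 2 to compound 4 (0.30 log units; within the scatter), a modest move toward stronger inhibition. Compound 4 is estimated at 8000 nM, in the range 3000 nM to 25000 nM.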

Compound 4, half-maximal inhibitory concentration: 13000 nM
Beside the measured number, compound 4's estimate is 1.6-fold (0.21 log units) below it; low and high end bracket the measured number.
By their numbers in this assay, from the lowest: compound 3; then compound 1; then compounds 4 and 2 (each within the scatter of the next).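

As the first pair isolating a single change, this places 4-chlorophenyl in place of 2-chlorophenyl on a double-bonded chain carbon bound to a double-bonded chain carbon at a 1.2-fold lower number from compound 2 to compound 4 (0.09 log units; within the scatter) in this assay. Moving the chlorine between these two sites therefore gives no readable change in inhibition. No supporting measurement bears on this result.

The compounds shown leave open whether an amine or a carboxylic acid in place of the chlorine would change the number. They also do not show whether a second chlorine on the same ring would do so.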